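Adding a Methyl to the Five-Membered Ring Nitrogen

The source may hold more compounds than are shown below. What is called first, only, known or untested is meant among the compounds shown, and "the series" means these compounds.

Measured so far:
compound 1 `CCCn1c(=O)c2nc[nH]c2n(C)c1=O`, 3400 nM
compound 2 `CCCn1c(=O)n(C)c(=O)c2[nH]cnc21`, 1900 nM
compound 3 `CCCn1c(=O)n(CC)c(=O)c2[nH]cnc21`, 1400 nM

All three compounds share one core and were tested in an assay on membranes from brain for displacement of a labelled ligand from adenosine receptor A1 (Cavia porcellus); a higher number here means a weaker inhibitor, a lower number a stronger inhibitor. Within the data shown here, compound 3 gives the lowest of the three numbers; its nearest neighbour is compound 2, and the only measured single step, a 1.4-fold lower number from compound 2 to compound 3 (0.13 log units; within the scatter), stays within the scatter. Compound 1 stands further away, and the gap between compound 1 and compound 3 is beyond the scatter, so compound 3 can be placed as the strongest inhibitor among the measured set.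

Compound 4 `CCCn1c(=O)n(CC)c(=O)c2c1ncn2C` differs from compound 3 in one place: methyl in place of hydrogen on an aromatic nitrogen. Among the measured compounds shown here, none of the measured steps touches this ring nitrogen; the only step in hand, from compound 2 to compound 3, concerns a saturated chain carbon on a different nitrogen and was small. There is therefore no measured guide for the size or direction of this change, and the expectation for this assay must be wide.

Compound 4 is estimated at 12000 nM, with a range from 3000 nM to 50000 nM. This estimate means an expected step of an 8.6-fold higher number from compound 3 to compound 4 (0.93 log units; beyond the scatter), a weaker inhibitor, held with low confidence.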

Compound 4, inhibition constant: 11800 nM
Estimate against measurement, compound 4: 1.0-fold (0.01 log units) above; the range from low to high includes it.
By their numbers in this assay, from the lowest: compounds 3, 2 and 1 (each within the scatter of the next, the first and the last beyond it); then compound 4.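

In this assay, among these compounds, the swap of hydrogen for methyl on this aromatic nitrogen gives an 8.4-fold higher number from compound 3 to compound 4 (0.93 log units; beyond the scatter) and so makes a weaker inhibitor, the first single step in this set that lies beyond the scatter. The earlier step of a 1.4-fold lower number from compound 2 to compound 3 (0.13 log units; within the scatter) also put a methyl in place of a hydrogen, but on a saturated chain carbon, and it stayed within the scatter, so in these two steps the same small addition counts for much more on the ring nitrogen than on that chain. Nothing available here explains why this position responds so strongly.

The single change both removes the hydrogen from the ring nitrogen and adds the methyl, and the compounds shown cannot separate those two events. Also open, from the compounds shown here alone, is what a longer chain, or a chain ending in an amine or a carboxylic acid, would do on this same nitrogen, and whether the loss seen with methyl would deepen, level off or reverse.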